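Chloro to Iodo: A Step Without a Measured Precedent

The source may hold more compounds than are shown below. What is called first, only, known or untested is meant among the compounds shown, and "the series" means these compounds.

Compound 1 `Cc1sc(N)c(C(=O)c2cccc3ccccc23)c1C`: 18%
Compound 2 `COc1ccc(C(=O)c2c(N)sc3c2CCC3)c2ccccc12`: 57%
Compound 3 `Nc1sc2c(c1C(=O)c1ccc(Cl)c3ccccc13)CCC2`: 0%

In an assay on isolated protein with adenosine receptor A3 (Homo sapiens) as the target, tested at 10 uM (a higher number here means more inhibition at the concentration tested (going by the name of the read-out), a lower number less inhibition), compound 3 gives the lowest of the three numbers, with compound 1 standing above it beyond the scatter and compound 2 standing highest of all. Compound 4 `Nc1sc2c(c1C(=O)c1ccc(I)c3ccccc13)CCC2` differs from compound 3 by iodo in place of chloro on an aromatic carbon. Within the data shown here, the one measured step at this position is a number 57 percentage points lower from compound 2 to compound 3 (beyond the scatter), a change from a methoxy to a halogen rather than from one halogen to another, so it guides only loosely. Among the measured compounds shown here, because compound 3 sits at 0%, little room remains downward, and no measured step points upward, so the expected step is a number 8 percentage points higher from compound 3 to compound 4 (within the scatter), within the scatter. Compound 4 is expected to give 8%, estimated between 0% and 30%.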

Compound 4, a percentage reported as inhibition, at one concentration (the size of the read-out at that concentration, not a potency): 0%
Beside the measured number, compound 4's estimate is 8 percentage points above it, within the range that was stated.
By their numbers in this assay, from the lowest: compounds 3 and 4 (each within the scatter of the next); then compound 1; then compound 2.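

In this assay, exchanging one halogen for another at this position gives no change at the digits printed from compound 3 to compound 4 (within the scatter), so chloro and iodo cannot be told apart here. The drop seen with chloro is not particular to that atom, since iodo in place of methoxy gives a number 57 percentage points lower from compound 2 to compound 4 (beyond the scatter). Nothing available explains why methoxy differs from the two halogens. Going by these compounds, whether an amine or a hydroxyl group at this place would give a number nearer that of compound 2 remains open. So does whether a methoxy group would have the same effect on the core of compound 1.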